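The compounds below may be only part of what the source reports. "The series", "measured", "known", "first", "only" and "open" are said of these compounds alone.

Among the measured compounds shown here, compound 1, `CC(C)(C)c1ccc(CNCCCNS(=O)(=O)c2cc(C(F)(F)F)cc(C(F)(F)F)c2)cc1`, is one of three compounds measured in a functional assay on PANC-1 cells (Homo sapiens) for inhibition, read by MTT assay, with a stated time of 72 h (a lower number here means a stronger inhibitor of growth, a higher number a weaker inhibitor of growth), where compound 1 gives 2500 nM. Compound 2, `O=S(=O)(NCCCNCc1ccc(-c2ccccc2)cc1)c1cc(C(F)(F)F)cc(C(F)(F)F)c1`, gives 2500 nM, so that no change at the digits printed from compound 1 to compound 2 (within the scatter); the two stand level, together the lowest of the three numbers. Compound 3, `O=S(=O)(NCCCNCc1ccc(Cl)c(C(F)(F)F)c1)c1cc(C(F)(F)F)cc(C(F)(F)F)c1`, gives 10000 nM, and here a 4.0-fold higher number from compound 1 to compound 3 (0.60 log units; beyond the scatter), a modest weakening.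

Compound 4, `O=S(=O)(NCCCNCc1ccc(Br)cc1)c1cc(C(F)(F)F)cc(C(F)(F)F)c1`, differs from compound 1 in one place: bromo in place of tert-butyl on an aromatic carbon. For the measured compounds named here, two measured steps bear on this. The step from compound 1 to compound 2, in which phenyl replaces tert-butyl on the same aromatic carbon, stayed within the scatter, while the step from compound 1 to compound 3, which puts 4-chloro-3-(trifluoromethyl)phenyl in place of 4-(tert-butyl)phenyl on the saturated chain carbon bound to the amine nitrogen, weakened growth inhibition beyond the scatter. A halogen now enters at the aromatic carbon, as in compound 3, but only one heavy atom and nothing more. Compound 4 is therefore expected to sit between these two outcomes, with a 1.6-fold higher number from compound 1 to compound 4 (0.20 log units; within the scatter) as the estimated step, leaning toward a small loss. Compound 4 is estimated at 4000 nM, with a range from 1500 nM to 11000 nM.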

Compound 4, concentration for 50% growth inhibition: 2200 nM
The estimate for compound 4 lay 1.8-fold (0.26 log units) above the measured number, and the stated range covers the measured number.
By their numbers in this assay, from the lowest: compounds 4, 1 and 2 (each within the scatter of the next); then compound 3.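

In this assay, the aromatic carbon para to a large group takes bromo, with its 1 heavy atom, much as it takes tert-butyl, with its 4 heavy atoms, showing a 1.1-fold lower number from compound 1 to compound 4 (0.06 log units; within the scatter), and the same holds against phenyl, with a 1.1-fold lower number from compound 2 to compound 4 (0.06 log units; within the scatter), so the three groups cannot be told apart at this position. A halogen at this carbon therefore does not on its own go with the higher number of compound 3, since 4-bromophenyl in place of 4-chloro-3-(trifluoromethyl)phenyl gives a 4.5-fold lower number from compound 3 to compound 4 (0.66 log units; beyond the scatter), although that change alters more than the halogen and cannot assign the difference to chloro or to trifluoromethyl. No measurement shown here offers an explanation for these numbers.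

The compounds shown leave open whether the position would stay as flat with a hydroxyl, an amine or a carboxylic acid there, or with hydrogen alone. They also leave open whether a 4-chlorophenyl or a 3-(trifluoromethyl)phenyl group would separate the two parts of the change in compound 3, and whether a longer chain would alter this picture.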